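A few compounds are considered here, and "the series" means these few. Any claim that something is new, unique, unknown or untested is made for them only; others in the source may bear on it.

Of the compounds shown here, three have so far been measured in a functional assay on MCF7 cells (Homo sapiens) for antiproliferative activity, read by MTT assay, with a stated time of 72 h; on this read-out higher numbers stand for weaker inhibition and lower numbers for stronger inhibition. Compound 1 `O=c1c(Cl)c(CSC(=S)N2CCCCC2)oc2ccccc12` gives 1000 nM, compound 3 `O=c1c(Cl)c(CSC(=S)N2CCCC2)oc2ccccc12` gives 2300 nM, and compound 2 `COc1ccc2occ(CSC(=S)N3CCCC3)c(=O)c2c1` gives 34100 nM. Compound 2 thus carries the highest of the three numbers, with compound 3 nearest to it and compound 1 furthest away. The cores of compound 2 and compound 3 are not the same, and the difference between them is not broken down here; only their two values can be set side by side.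

Compound 1 and compound 3 differ in a single place: piperidin-1-yl in place of pyrrolidin-1-yl on a thiocarbonyl carbon. That change produced a 2.3-fold lower number from compound 3 to compound 1 (0.36 log units; beyond the scatter).

Compound 4 `COc1ccc2occ(CSC(=S)N3CCCCC3)c(=O)c2c1` has not yet been measured in this assay. It stands to compound 2 exactly as compound 1 stands to compound 3: piperidin-1-yl in place of pyrrolidin-1-yl on a thiocarbonyl carbon. The place is described in the same words for both pairs, so this is the same change, here made on the core of compound 2 rather than on that of compound 3. Going by the values given here, the expectation for compound 4 rests on the one measured example, a 2.3-fold lower number from compound 3 to compound 1 (0.36 log units; beyond the scatter), while allowing that a single precedent on a different core is a thin basis. The expected step is a 2.3-fold lower number from compound 2 to compound 4 (0.36 log units; beyond the scatter). Compound 4 is accordingly estimated to give 15000 nM, within a range from 7000 nM to 32000 nM.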

Compound 4, half-maximal inhibitory concentration: > 40000 nM
Compound 4: only a limit was reported; the forecaster's own chance of this, stated with the estimate: 5%; middle value at least 2.6-fold (0.42 log units) from the limit.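

In this assay, compound 4 gives > 40000 nM, which is a limit of the assay and not a number. Piperidin-1-yl in place of pyrrolidin-1-yl on a thiocarbonyl carbon gave an at least 1.1-fold higher number from compound 2 to compound 4 (0.06 log units; that floor lies within the scatter), so the lowering seen on the chlorinated core of compound 3 did not carry over to the core of compound 2, and the two steps differ: the same change on two cores in this assay, a 2.3-fold lower number (0.36 log units; beyond the scatter) from compound 3 to compound 1 and an at least 1.1-fold higher number (0.06 log units; that floor lies within the scatter) from compound 2 to compound 4, at least 2.6-fold (0.43 log units) apart, beyond the scatter of two such steps. Going by these compounds, this shows that the effect of the change depends on the core, but the true size of the step on the core of compound 2 stays unknown, and even its direction is not settled because the value of compound 4 is only a limit: the limit of > 40000 nM in this assay, at which 1 of the 4 values shown sits.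

The cores of the two pairs differ in more than one place, so the compounds shown cannot tell whether the chloro group, the methoxy group or some other difference between the cores separates the two results. They also leave open how an open-chain diethylamine or a morpholine on the same thiocarbonyl carbon would behave on each core, and whether a core carrying both the chloro and methoxy groups would follow the pattern of compound 3 and compound 1.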